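Swapping Hydroxy for Methyl on the Aniline Ring

The compounds below may be only part of what the source reports. "The series", "measured", "known", "first", "only" and "open" are said of these compounds alone.

Compound 2 `Cc1ccc(Nc2nc(-c3ccncc3)cs2)cc1O` gives 12000 nM in a functional assay on RCC4 cells (Homo sapiens) for inhibition, read by XTT assay, with a stated time of 4 days (on this read-out higher numbers stand for weaker inhibition and lower numbers for stronger inhibition), the highest of the two numbers measured; its nearest neighbour is compound 1 `Cc1ccc(Nc2nc(-c3ccncc3)cs2)cc1`, which in this assay gives 2510 nM. The step of a 4.8-fold higher number from compound 1 to compound 2 (0.68 log units; beyond the scatter) is the only one available. Compound 3 `Cc1ccc(Nc2nc(-c3ccncc3)cs2)cc1C` differs from compound 2 by methyl in place of hydroxy on an aromatic carbon. Among the measured compounds shown here, no measured pair shows a methyl taking the place of a hydroxy, so the change can only be judged against compound 1, where a hydrogen sits at that carbon: adding the hydroxy in compound 2 went with a weaker number than compound 1, and taking it away again may undo part of that. The step of a 3.4-fold lower number from compound 2 to compound 3 (0.54 log units; beyond the scatter) is therefore expected to lower the number, though a methyl is not a hydrogen and the size remains uncertain. Compound 3 is estimated at 3500 nM, with a range from 1200 nM to 10000 nM.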

Compound 3, half-maximal inhibitory concentration: 6610 nM
The estimate for compound 3 lay 1.9-fold (0.28 log units) below the measured number; low and high end bracket the measured number.
By their numbers in this assay, from the lowest: compound 1; then compounds 3 and 2 (each within the scatter of the next).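

The swap at this carbon, read in this assay as a 1.8-fold lower number from compound 2 to compound 3 (0.26 log units; within the scatter) here, shows that hydroxy and methyl cannot be told apart at this position, although hydroxy carries a hydrogen-bond donor and acceptor and methyl carries neither. The comparison with hydrogen, a 2.6-fold higher number from compound 1 to compound 3 (0.42 log units; beyond the scatter) for methyl, adds a second group that goes with weaker inhibition than hydrogen, as hydroxy does in a 4.8-fold higher number from compound 1 to compound 2 (0.68 log units; beyond the scatter) here. Among these three compounds, hydrogen at this carbon therefore gives the lowest number, and none goes against that, whereas the earlier pair alone could not say whether this held for hydroxy only.

From the compounds shown here alone, whether an amine, a fluorine atom or a longer chain such as ethyl at this carbon would also give a higher number than compound 1 stays open. Why both groups go with higher numbers than hydrogen also stays open, and no supporting measurement is at hand.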